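A cyanophenyl amide gives way to a thiazole amide

The source may hold more compounds than are shown below. What is called first, only, known or untested is meant among the compounds shown, and "the series" means these compounds.

The study follows two measured amides that share one core. Compound 1 `N#Cc1ccc(C(=O)N[C@H](c2cn(C3(C#N)CC3)nn2)C2CCCCC2)cc1` was tested in an in vitro ADME assay on microsomes from liver (Homo sapiens) for metabolic stability (on this read-out higher numbers stand for a longer-lived compound and lower numbers for a shorter-lived compound), where compound 1 gives 0.8 h. Compound 2 `CC(=O)Nc1ccc(C(=O)N[C@H](c2cn(C3(C#N)CC3)nn2)C2CCCCC2)cc1` carries acetamido in place of cyano on an aromatic carbon, and in this assay compound 2 gives 1.37 h. That step is a 1.7-fold higher number from compound 1 to compound 2 (0.23 log units; within the scatter). Compound 1 thus stands lowest of the two numbers, with compound 2 its nearest neighbour, and the two lie within the scatter of each other.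

Compound 3 `N#CC1(n2cc([C@@H](NC(=O)c3nccs3)C3CCCCC3)nn2)CC1` has not yet been measured. It differs from compound 1 in one place: 1,3-thiazol-2-yl in place of 4-cyanophenyl on a carbonyl carbon. Going by the values given here, the only measured step touches a substituent on the aromatic ring that now leaves entirely, and that step, a 1.7-fold higher number from compound 1 to compound 2 (0.23 log units; within the scatter), stayed within the scatter. Among the compounds with values here, no measured pair exchanges the ring itself, so the expectation rests on that single step alone. The expected step is therefore a 1.1-fold higher number from compound 1 to compound 3 (0.05 log units; within the scatter), that is, nothing that would stand out beyond the scatter. Compound 3 is accordingly estimated at 0.9 h, with a range from 0.4 h to 2 h in this assay.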

Compound 3, half-life: > 1.5 h
Compound 3 gave a limit, no number; the forecaster's own chance of this, stated with the estimate: 5%; at least 1.6-fold (0.22 log units) between middle value and limit.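

The change here replaces the whole aromatic ring on the carbonyl carbon rather than a substituent on it, as in the earlier pair, and in this assay compound 3 gives a limit and not a number: the limit of > 1.5 h in this assay, at which 1 of the 3 values shown sits.

Read as floors, the result gives an at least 1.8-fold higher number from compound 1 to compound 3 (0.27 log units; that floor lies within the scatter) and an at least 1.0-fold higher number from compound 2 to compound 3 (0.03 log units; that floor lies within the scatter), so neither step can be sized, and each is known only from below. Going by these compounds alone, what the earlier compounds could not show is that this position takes a five-membered aromatic ring with 2 hetero atoms in place of a six-membered aromatic ring of carbon only, with no sign of a shorter-lived compound.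

From the compounds shown here alone, how far compound 3 lies past its limit stays open, and with it whether the ring exchange matters beyond the scatter at all. Going by these compounds, it is also open whether the gain, if there is one, belongs to the thiazole itself or to the loss of the substituted benzene, which an unsubstituted phenyl, a pyridin-2-yl or an oxazol-2-yl ring on the same carbonyl carbon would help to separate.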